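Series notes: remote substituent swap and the acid dissociation constant

This account rests on a few compounds, and the source may have more. Where it says the series, first, only, none or still open, it means among the compounds named here.

Three compounds of the shared core have been run in a physicochemical assay for acid dissociation. Compound 1 `COc1ccc(F)cc1CNCCCNc1ccnc2cc(Cc3ccc(C#N)cc3)ccc12` gives 9.47. Compound 2 `CN(C)c1cccc(Oc2ccc3c(NCCCNCc4ccco4)ccnc3c2)c1` gives 9.28. Compound 3 `COc1cccc(CNCCCNc2ccnc3cc(CCC(C)C)ccc23)c1O` gives 9.47. Compound 1 stands level with compound 3 at the digits shown, and the two of them sit at the top of the three numbers; the gap from compound 1 down to compound 2 lies within the scatter of this assay, so none of the three can be ordered against the others.

Compound 4 `COc1ccc(F)cc1CNCCCNc1ccnc2cc(CC3CCCCC3)ccc12` has not yet been measured. It differs from compound 1 in one place: cyclohexyl in place of 4-cyanophenyl on a saturated chain carbon bound to an aromatic carbon. The change sits on the far side of the core from the chain that carries the secondary amine and the aromatic amine, and compound 3, which carries a plain saturated chain at that same position, gives the same number as compound 1. Within the data shown here, no step between measured compounds is available for this kind of change, so the expectation rests only on those two values.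

On that basis the step from compound 1 to compound 4 is expected to be no change at the digits printed from compound 1 to compound 4 (within the scatter), that is, nothing beyond the scatter. Compound 4 is estimated at 9.47, with a range from 9.2 to 9.75.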

Compound 4, acid dissociation constant: 9.47
The estimate for compound 4 equals the measured number at the digits printed, within the range that was stated.
By their numbers in this assay, from the lowest: compounds 2, 1, 3 and 4 (each within the scatter of the next).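

In this assay, among these compounds, the replacement of 4-cyanophenyl by cyclohexyl on a saturated chain carbon bound to an aromatic carbon gives no change at the digits printed from compound 1 to compound 4 (within the scatter) and is the first step that can be read between two compounds differing in one place. The exchange takes out a six-membered aromatic ring of carbon only, the triple bond of the nitrile and the hydrogen-bond acceptor of the leaving group, and puts in a six-membered non-aromatic ring of carbon only, so at this position a swap of that extent, also readable as 4-cyanobenzyl to cyclohexylmethyl, stays within the scatter of this read-out. No supporting measurement bears on this result, and the step stands as an observation only.

From the compounds shown here alone, both groups in this single step carry no net charge, so it remains open whether an amine or a carboxylic acid on the same saturated chain carbon would leave the number in this assay equally unmoved. Going by these compounds, it is also open whether the same exchange gives the same step when the rest of the molecule differs from compound 1.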